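Tail flick activity after swapping the side chain of compound 1

The source may hold more compounds than are shown below. What is called first, only, known or untested is meant among the compounds shown, and "the series" means these compounds.

Measured so far:
- compound 1 `N=C(N)NCCC[C@H](NC(=O)CN(c1ncnc2c1ncn2C1CCCCO1)C1CC1)C(=O)OCc1ccccc1`: 61.6%
- compound 2 `C[C@H](NC(=O)CN(c1nc(Cl)nc2[nH]cnc12)C1CC1)C(=O)OCc1ccccc1`: 44.2%
- compound 3 `CC(C)[C@H](NC(=O)CN(c1nc(Cl)nc2[nH]cnc12)C1CC1)C(=O)O`: 30.3%

In a functional assay on the whole organism (Tail, strain ICR) with Mus musculus as the target, in the tail flick test, with a stated time of 90 min, at a dose of 25 umol/kg by the oral route (a lower number here means a weaker effect, a higher number a stronger effect of the compound at the dose given), compound 1 gives 61.6%, the highest of the three numbers. Compound 2 lies beyond the scatter below it, and compound 3 lies further below still. Compound 4 `NC(=O)C[C@H](NC(=O)CN(c1ncnc2c1ncn2C1CCCCO1)C1CC1)C(=O)OCc1ccccc1` differs from compound 1 in one place: a group of 3 heavy atoms (1 carbon, 1 nitrogen, 1 oxygen; no ring) in place of a group of 6 heavy atoms (3 carbon, 3 nitrogen; no ring), on a saturated chain carbon, two bonds along the chain from an amide-type nitrogen and a carbonyl carbon. For the measured compounds named here, the entering carbamoyl group is smaller than the group it replaces, and no step between measured compounds of this kind is available to guide the size of the effect. A moderate loss, beyond the scatter, is expected in this assay, as a number 17.6 percentage points lower from compound 1 to compound 4 (beyond the scatter). Compound 4 is therefore estimated at 44%, with a range from 24% to 64%.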

Compound 4, a percentage reported as activity, at one dose (the size of the read-out at that dose, not a potency): 35%
The estimate for compound 4 lay 9 percentage points above the measured number, within the range that was stated.
By their numbers in this assay, from the lowest: compounds 3, 4 and 2 (each within the scatter of the next, the first and the last beyond it); then compound 1.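

In this assay, for the compounds shown here, carbamoyl in place of the group of 6 heavy atoms gives a number 26.6 percentage points lower from compound 1 to compound 4 (beyond the scatter) and so offers the first direct reading of a single change at this saturated chain carbon. The side chain here therefore affects the response at the dose given, with the shared core unchanged. Nothing available explains this drop.

From the compounds shown here alone, whether an amine, a carboxylic acid or a longer chain ending in carbamoyl at this carbon would keep more of the effect remains open.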